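The compounds below may be only part of what the source reports. "The series", "measured", "known", "first", "only" and "open" are said of these compounds alone.

Compound 1 `COc1ccccc1/C=C/c1ccccc1OCCCCN(C)C`: 0%
Compound 2 `OC1CCN(CCCCOc2ccccc2/C=C/c2ccccc2)CC1`: 0%

In a functional assay on the whole organism with Mus musculus as the target, in the maximal electroshock model, at a dose of 50 mg/kg by the oral route (on this read-out higher numbers stand for more inhibition at the one dose given (going by the name of the read-out) and lower numbers for less inhibition), compound 1 gives 0%. In this assay compound 2 gives 0%, which is level with compound 1 at the digits shown, within the usual scatter. Compound 3 `CC(=O)N1CCN(CCCCOc2ccccc2/C=C/c2ccccc2)CC1` differs from compound 2 in one place: 4-acetylpiperazin-1-yl in place of 4-hydroxypiperidin-1-yl on a saturated chain carbon, four bonds along the chain from an oxygen on an aromatic ring. Among the compounds with values here, no measured pair shows how such a change moves this read-out, and both measured compounds sit at the bottom of the scale. No step beyond the scatter is expected, so the estimated step of no change at the digits printed from compound 2 to compound 3 (within the scatter) is small. Compound 3 is expected to give 0%, within 0% to 20%.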

Compound 3, a percentage reported as inhibition, in the whole organism at one dose (the size of the read-out at that dose, not a potency): 0%
Compound 3: middle estimate and measured number agree at the digits printed, and the stated range covers the measured number.
By their numbers in this assay, from the lowest: compounds 1, 2 and 3 (each within the scatter of the next).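

Placing 4-acetylpiperazin-1-yl where 4-hydroxypiperidin-1-yl stood, on the saturated chain carbon, gives no change at the digits printed from compound 2 to compound 3 (within the scatter) in this assay, so this larger ring with a second ring nitrogen and no hydrogen-bond donor does not lift the read-out off the bottom of the scale. With all the values at the floor, the result cannot show whether this position matters at all. No measurement here offers an explanation for this result.

From the compounds shown here alone, whether a morpholine ring or a carboxylic acid at this place, or a longer chain, would give any inhibition remains open.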